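The source may hold more compounds than are shown below. What is called first, only, known or untested is meant among the compounds shown, and "the series" means these compounds.

Of the compounds shown here, three built on one shared core have been tested in an ADME assay on microsomes from liver (Homo sapiens) for metabolic stability, with a stated time of 10 min; a higher number here means that more of the compound is left, a lower number that less of the compound is left. Compound 1 `CC(C)(C)NC(=O)NCCS(=O)(=O)NC(=O)c1ccc(Nc2nc(NC3(c4ccc(Cl)cc4)CC3)nc(OCC(F)(F)F)n2)cc1` gives 96% in this assay. Compound 2 `O=C(NS(=O)(=O)CCNC(=O)C1CC1)c1ccc(Nc2nc(NC3(c4ccc(Cl)cc4)CC3)nc(OCC(F)(F)F)n2)cc1` gives 90%. Compound 3 `CC(C)NC(=O)NCCS(=O)(=O)NC(=O)c1ccc(Nc2nc(NC3(c4ccc(Cl)cc4)CC3)nc(OCC(F)(F)F)n2)cc1` gives 100%, the highest of the three numbers, though its steps to the others, a number 4 percentage points higher from compound 1 to compound 3 (within the scatter) and a number 10 percentage points higher from compound 2 to compound 3 (within the scatter), both lie within the scatter. Compound 4 `CNC(=O)NCCS(=O)(=O)NC(=O)c1ccc(Nc2nc(NC3(c4ccc(Cl)cc4)CC3)nc(OCC(F)(F)F)n2)cc1` differs from compound 3 by methyl in place of isopropyl on an amide-type nitrogen. The closest comparison already measured is the change from tert-butyl to isopropyl on that same nitrogen, which gave a number 4 percentage points higher from compound 1 to compound 3 (within the scatter), and the cyclopropyl swap gave a number 6 percentage points lower from compound 1 to compound 2 (within the scatter), also within the scatter. Shortening the chain again is therefore expected to give a step of a number 4 percentage points lower from compound 3 to compound 4 (within the scatter), nothing beyond the scatter. Compound 4 is estimated at 96%, between 85% and 100%.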

Compound 4, percent of the compound remaining: 97%
Beside the measured number, compound 4's estimate is 1 percentage points below it; measured number inside the range.
By their numbers in this assay, from the lowest: compounds 2, 1, 4 and 3 (each within the scatter of the next).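

In this assay, going down to methyl on the amide-type nitrogen gives a number 3 percentage points lower from compound 3 to compound 4 (within the scatter) and a number 1 percentage points higher from compound 1 to compound 4 (within the scatter) so methyl, isopropyl and tert-butyl cannot be told apart at this position. Methylamino in place of cyclopropyl on the carbonyl carbon gives a number 7 percentage points higher from compound 2 to compound 4 (within the scatter) so that swap cannot be read as a real change either. Nothing at hand explains this tolerance. Going by these compounds, what remains open is whether a group that adds an amine, a carboxylic acid or a longer chain on that nitrogen would move the number beyond the scatter.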